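A few compounds are considered here, and "the series" means these few. Any claim that something is new, unique, unknown or untested is made for them only; others in the source may bear on it.

Working notes on the series. Compound 1 `Oc1cc(C(F)(F)F)ccc1-c1nc(-c2ccccc2O)n(-c2ccc(F)cc2)n1` in a functional assay on PC-12 cells (Rattus norvegicus) for cytotoxicity, read by MTT assay, with stated times of 2 h and 24 h, tested at 10 uM (on this read-out higher numbers stand for a stronger effect at the one concentration tested and lower numbers for a weaker effect), gives 99.8%. Compound 2 `Oc1cc(C(F)(F)F)ccc1-c1nc(-c2ccccc2O)n(-c2ccc(C(F)(F)F)cc2)n1` in this assay gives 102%. Going by the values given here, on these two numbers compound 1 stands lowest, with compound 2 nearest; the one measured step between them, a number 2.2 percentage points higher from compound 1 to compound 2 (within the scatter), is trifluoromethyl in place of fluoro on an aromatic carbon and lies within the scatter, so the two numbers are treated as the same.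

Compound 3 `Oc1cc(C(F)(F)F)ccc1-c1nc(-c2ccccc2O)n(-c2ccccc2Cl)n1` is not yet measured in this assay. Its change from compound 1 is 2-chlorophenyl in place of 4-fluorophenyl on an aromatic nitrogen. Among the compounds with values here, the only measured step that bears on it is the one already given, which also altered the aryl group on the aromatic nitrogen of the shared core and moved the number by a number 2.2 percentage points higher from compound 1 to compound 2 (within the scatter). With both measured numbers near the full value and that step within the scatter, no step beyond the scatter is expected in either direction.

For compound 3 the expected value in this assay is 99%, with a range from 86% to 110%. The step this estimate means, a number 0.8 percentage points lower from compound 1 to compound 3 (within the scatter), is expected to stay within the scatter.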

Compound 3, a percentage reported as activity, at one concentration (the size of the read-out at that concentration, not a potency): 102%
The estimate for compound 3 lay 3 percentage points below the measured number; the measured number falls inside the stated range.
By their numbers in this assay, from the lowest: compounds 1, 2 and 3 (each within the scatter of the next).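

On the aromatic nitrogen of the shared core, 2-chlorophenyl in place of 4-fluorophenyl gives a number 2.2 percentage points higher from compound 1 to compound 3 (within the scatter) in this assay, and 2-chlorophenyl in place of 4-(trifluoromethyl)phenyl gives no change at the digits printed from compound 2 to compound 3 (within the scatter) in the same read-out. Going by these compounds alone, the earlier pair covered only two phenyl groups substituted at the 4-position, so these steps are the first to show that the number also holds with 2-chlorophenyl at this position, although the halogen and its place on the phenyl change together and cannot be told apart here. No measurement on hand explains why the three numbers agree.

All three aryl groups shown carry fluoro, trifluoromethyl or chloro, so it remains open whether an aminophenyl group, a phenyl group bearing a carboxylic acid, or a plain butyl chain on this nitrogen would leave the number in this assay unchanged. On these data alone, with a single concentration behind each number, it also remains open whether the three compounds would still agree at other concentrations.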